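Chloro Added to the Benzo Ring of Compound 3

The compounds below may be only part of what the source reports. "The series", "measured", "known", "first", "only" and "open" are said of these compounds alone.

Measured so far:
compound 1 `Cc1cc(Cl)c2oc(N3CCN(C)CC3)nc2c1`: 6.22
compound 2 `COc1cc(Cl)cc2nc(N3CCN(C)CC3)oc12`: 6.16
compound 3 `CN1CCN(c2nc3cccc(Cl)c3o2)CC1`: 5.5

In a functional assay on ileum (strain Hartley) for agonist activity at 5-hydroxytryptamine receptor 3A (Cavia porcellus) (on this read-out higher numbers stand for higher potency (the scale is a negative logarithm) and lower numbers for lower potency), compound 3 stands lowest of the three; compound 2 lies higher beyond the scatter, and compound 1 higher still. Compound 4 `CN1CCN(c2nc3cc(Cl)cc(Cl)c3o2)CC1` differs from compound 3 by chloro in place of hydrogen on an aromatic carbon. Going by the values given here, the only measured step bearing on this change is a number 0.72 log units lower from compound 1 to compound 3 (beyond the scatter), where a small group left an aromatic carbon of the same ring and potency fell modestly. Returning a small group, here a chloro, is therefore expected to raise potency in this assay by a modest amount, about a number 0.60 log units higher from compound 3 to compound 4 (beyond the scatter). Compound 4 is thus estimated at 6.1, with a range from 5.6 to 6.6.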

Compound 4, negative logarithm of the half-maximal effective concentration: 6.51
For compound 4 the middle estimate is 0.41 log units below the measured one, within the range that was stated.
By their numbers in this assay, from the lowest: compound 3; then compounds 2, 1 and 4 (each within the scatter of the next, the first and the last beyond it).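

In this assay, chloro in place of hydrogen at this carbon, meta to a chloro group, gives a large rise (a number 1.01 log units higher from compound 3 to compound 4 (beyond the scatter)), which shows directly that a substituent here can raise potency. Methyl and chloro at this carbon cannot be told apart (a number 0.29 log units higher from compound 1 to compound 4 (within the scatter)), so the two groups serve about equally. At the other substituted carbon of the ring, chloro in place of methoxy gives a modest rise (a number 0.35 log units higher from compound 2 to compound 4 (beyond the scatter)).

No evidence is available to explain these steps. From the compounds shown here alone, whether an amine, a carboxylic acid or a longer chain at this carbon would keep this potency remains open.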